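The source may report more compounds than this note shows. Statements on the series, on what has been measured and on what is new or still open speak of the compounds shown alone.

Compounds measured in a functional assay on HEK293 cells for agonist activity at growth hormone secretagogue receptor type 1 (Homo sapiens), read by HTRF and inositol phosphate accumulation, with a stated time of 90 min, in the presence of a further agent that is not named here; a lower number here means a smaller maximal response, a higher number a larger maximal response:

Compound 1, `Cc1ccc2[nH]c(C(=O)N[C@H]3CCN(S(=O)(=O)C4CC4)C[C@@H]3C(=O)NCCN(C)C)cc2c1`: 95%
Compound 2, `Cc1ccc2[nH]c(C(=O)N[C@H]3CCN(S(=O)(=O)c4ccccc4Cl)C[C@@H]3C(=O)N[C@H]3CCCNC3)cc2c1`: 97%
Compound 3, `O=C(N[C@H]1CN(S(=O)(=O)c2ccccc2)C[C@@H]1C(=O)N1C[C@H]2CCNC[C@H]21)c1cc(-c2ccccc2Cl)on1`: 98%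

In this assay compound 3 gives the highest of the three numbers, yet its gap to compound 2 and its gap to compound 1 both lie within the usual scatter, so the three compounds cannot be put in order on these values. All three reach close to the full response of the reference.

Compound 4, `O=CN1CCC[C@H](NC(=O)[C@H]2CN(S(=O)(=O)c3ccccc3)C[C@@H]2NC(=O)c2cc(-c3ccccc3Cl)on2)C1`, has not yet been measured. Set beside compound 3, it differs in one place:

a group of 9 heavy atoms (6 carbon, 2 nitrogen, 1 oxygen; one six-membered non-aromatic ring with 1 hetero atom) in place of a group of 8 heavy atoms (6 carbon, 2 nitrogen; one four-membered non-aromatic ring with 1 hetero atom, one six-membered non-aromatic ring with 1 hetero atom), on a carbonyl carbon

Within the data shown here, no step between two measured compounds is available here, so nothing measured shows how this kind of change moves the largest response. The three measured compounds, differing widely in their amide parts, all stay near the reference response, which suggests that the amide part tolerates variation. The step of a number 8 percentage points lower from compound 3 to compound 4 (within the scatter) is therefore expected to be small, within or just beyond the scatter, and if anything downward. For compound 4 the estimate is 90%, with a range from 70% to 105%.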

Compound 4, largest response reached (Emax), in percent of the reference or control that the assay uses: 90%
Compound 4: middle estimate and measured number agree at the digits printed; low and high end bracket the measured number.
By their numbers in this assay, from the lowest: compounds 4, 1, 2 and 3 (each within the scatter of the next).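

In this assay, among these compounds, the group on this carbonyl carbon is exchanged in one place for the first time, and the step is a number 8 percentage points lower from compound 3 to compound 4 (within the scatter) with the rest of the molecule unchanged. The earlier compounds shown here differ in several places at once, whereas this pair shows that the largest response stays within the scatter when the group with a four-membered and a six-membered non-aromatic ring gives way to one with a single six-membered non-aromatic ring and a double bond outside aromatic rings. Nothing available gives a reason for the size of this step.

The compounds shown leave open how the largest response would move with a carboxylic acid or a morpholine ring on this carbonyl carbon. This single pair also cannot tell whether the same exchange would behave alike on the core of compound 1.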